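Rearranging the Side Chain of Compound 1

This account rests on a few compounds, and the source may have more. Where it says the series, first, only, none or still open, it means among the compounds named here.

Measured so far in a functional assay on CCRF-CEM cells (Homo sapiens) for antiproliferative activity; a higher number here means a weaker inhibitor of growth, a lower number a stronger inhibitor of growth:
- Compound 1 `COCCCCCCCCCCC/C=C1\CC(CO)(COC(=O)C(C)(C)C)OC1=O`: 0.701 ug/mL
- Compound 2 `CCCCCCCCC(O)CCCCCC/C=C1\CC(CO)(COC(=O)C(C)(C)C)OC1=O`: 5.72 ug/mL

Compound 1 has the lower of the two numbers, making it the stronger growth inhibitor of this pair. Compound 3 `CCCCCOCCCCCCC/C=C1\CC(CO)(COC(=O)C(C)(C)C)OC1=O` has not yet been measured. It contains the same atoms as compound 1, joined differently: pentyloxy in place of 4-methoxybutyl on a saturated chain carbon, seven bonds along the chain from a double-bonded chain carbon. Within the data shown here, only one measured step bears on this change, and only indirectly: an 8.2-fold higher number from compound 1 to compound 2 (0.91 log units; beyond the scatter). Among the measured compounds shown here, that step puts 1-hydroxynonyl in place of 5-methoxypentyl, which is a different exchange, and no measured compound carries pentyloxy. The two groups exchanged in compound 3 match in every count, so a step as large as that one is not expected in this assay. A slightly higher number is expected instead. The expected change is a 1.4-fold higher number from compound 1 to compound 3 (0.15 log units; within the scatter). Compound 3 is estimated at 1 ug/mL, with an expected range of 0.3 ug/mL to 3.5 ug/mL.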

Compound 3, concentration for 50% growth inhibition: 0.877 ug/mL
Beside the measured number, compound 3's estimate is 1.1-fold (0.06 log units) above it; low and high end bracket the measured number.
By their numbers in this assay, from the lowest: compounds 1 and 3 (each within the scatter of the next); then compound 2.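

In this assay, pentyloxy in place of 4-methoxybutyl, seven bonds along the chain from a double-bonded chain carbon, gives a 1.3-fold higher number from compound 1 to compound 3 (0.10 log units; within the scatter), so this rearrangement of the same atoms, which shifts the chain oxygen, leaves the read-out within the scatter. The exchange of (pentyloxy)methyl for 1-hydroxynonyl, six bonds along the chain from a double-bonded chain carbon, gives a 6.5-fold lower number from compound 2 to compound 3 (0.81 log units; beyond the scatter), which places compound 3 with compound 1 and apart from compound 2. Nothing measured here gives a reason for either result.

The compounds shown leave open whether the oxygen could sit elsewhere along the chain with the same outcome. They also leave open whether an amine in place of that oxygen, or a carboxylic acid at the chain end, would hold the number of compound 1.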